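The compounds below may be only part of what the source reports. "The series", "measured", "known", "first", "only" and "open" are said of these compounds alone.

In a functional assay on the whole organism (brain) with Mus musculus as the target (a lower number here means that less compound is needed, a higher number that more compound is needed for the effect), compound 1 (`COC(=O)c1ccc(OCCc2c[nH]cn2)cc1`) gives > 3 mg/kg, which is a limit of the assay and not a number. Its exact place is therefore unknown. Compound 2 (`O=C(c1ccccc1)c1ccc(OCCc2c[nH]cn2)cc1`), with phenyl in place of methoxy on a carbonyl carbon, gives 2.6 mg/kg. The measured step is an at least 1.1-fold lower number from compound 1 to compound 2 (0.06 log units; that floor lies within the scatter), so even a large change at this carbonyl carbon shows no firm shift. Compound 3 (`Clc1ccc(OCCc2c[nH]cn2)cc1`) carries chloro in place of methoxycarbonyl on an aromatic carbon, para to a group of 8 heavy atoms: chloro in place of methoxycarbonyl on an aromatic carbon. Among the measured compounds shown here, this removes the carbonyl altogether, so the one measured step bears on it only loosely. It gives no ground for expecting more than a small move towards a lower number in this assay, perhaps none beyond the scatter. The expected size is an at least 1.2-fold lower number from compound 1 to compound 3 (0.07 log units; that floor lies within the scatter). For compound 3, the estimated dose is 2.5 mg/kg, with an expected range of 0.8 mg/kg to 8 mg/kg.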

Compound 3, dose for half-maximal effect: 0.78 mg/kg
The estimate for compound 3 lay 3.2-fold (0.51 log units) above the measured number; the whole stated range lies above it.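

The position on the aromatic carbon, para to a group of 8 heavy atoms, now shows a firm effect: in this assay, chloro in place of methoxycarbonyl gives an at least 3.8-fold lower number from compound 1 to compound 3 (0.58 log units; beyond the scatter). Compound 2 changed only the group on the carbonyl carbon and gave no shift beyond the scatter, whereas this change removes the whole methoxycarbonyl, with its 4 heavy atoms and its 2 hydrogen-bond acceptors, and leaves 1 heavy atom and none. For compound 1, > 3 mg/kg is a limit of the assay and not a number, so this step gives only a floor: the limit of > 3 mg/kg in this assay, at which 1 of the 3 values shown sits.

This single change alters size, atoms and acceptors together, so the compounds shown cannot separate which of these matters. Going by these compounds, how an amine, a carboxylic acid or a longer chain at this place would compare remains open.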